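A Fluorophenyl Thioether Follows a Dichlorophenyl Thioether

The compounds below may be only part of what the source reports. "The series", "measured", "known", "first", "only" and "open" are said of these compounds alone.

Three compounds share one core, and in a functional assay on OVCAR-8 cells (Homo sapiens) for inhibition, read by sulforhodamine B assay, with a stated time of 48 h (on this read-out higher numbers stand for weaker inhibition of growth and lower numbers for stronger inhibition of growth), all of them sit near the upper edge of what was measured. Compound 1 `Nc1cc(N)c2nc(-c3ccccc3)c(Oc3ccc(Cl)c(Cl)c3)nc2c1` carries a 3,4-dichlorophenoxy group and in this assay gives 89100 nM. Compound 2 `COc1ccc(Sc2nc3cc(N)cc(N)c3nc2-c2ccccc2)cc1` carries a (4-methoxyphenyl)sulfanyl group in its place; in this assay compound 2 returns only a limit, < 100000 nM. Compound 3 `Nc1cc(N)c2nc(-c3ccccc3)c(Sc3ccc(Cl)c(Cl)c3)nc2c1` carries a (3,4-dichlorophenyl)sulfanyl group; in this assay compound 3 likewise returns only a limit, < 100000 nM. The steps a step that the limit leaves unreadable from compound 1 to compound 2, a step that the limit leaves unreadable from compound 1 to compound 3 and a step that the two limits leave unreadable from compound 2 to compound 3 cannot be sized, because the limit of < 100000 nM in this assay, at which 2 of the 3 values shown sit, hides where compounds 2 and 3 actually lie. Compound 4 `Nc1cc(N)c2nc(-c3ccccc3)c(Sc3ccc(F)cc3)nc2c1` differs from compound 3 by 4-fluorophenyl in place of 3,4-dichlorophenyl on a sulfur. For the measured compounds named here, none of the measured steps bears directly on exchanging one halogenated phenyl for another on the sulfur, and the single readable number, that of compound 1, lies close to the limit itself. The step that the limit leaves unreadable from compound 3 to compound 4 is therefore expected to be small, with no direction that stands out beyond the scatter. Compound 4 is estimated to give 70000 nM in this assay, within 25000 nM to 150000 nM, and a further limit rather than a number remains quite possible.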

Compound 4, concentration for total growth inhibition: 34700 nM
Beside the measured number, compound 4's estimate is 2.0-fold (0.30 log units) above it, and the stated range covers the measured number.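

For the compounds shown here, compound 4 is the first compound with a sulfur at this position to give a number rather than a limit in this assay, so a sulfur-linked aryl group can now be compared with the oxygen-linked group of compound 1. The exchange of 3,4-dichlorophenoxy for (4-fluorophenyl)sulfanyl is a 2.6-fold lower number from compound 1 to compound 4 (0.41 log units; beyond the scatter), a modest step but the first readable one in this set, and it points towards stronger inhibition of growth. The steps to compound 4 from compound 2 and from compound 3 cannot be read, so the exchange of 3,4-dichlorophenyl for 4-fluorophenyl on the sulfur has no size, and neither does the exchange of methoxy for fluoro on the aromatic carbon: the limit of < 100000 nM in this assay, at which 2 of the 4 values shown sit.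

The readable step changes the linking atom and the ring halogens together, and no compound shown differs from compound 4 in the linking atom alone, so how much of the step belongs to each remains open. Also open, going by these compounds, is how a phenyl ring carrying an amine or a carboxylic acid on the sulfur would read in this assay against the 4-fluorophenyl of compound 4.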